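The source may report more compounds than this note shows. Statements on the series, on what has been measured and on what is new or still open speak of the compounds shown alone.

This account concerns two compounds that share one core and one further compound built on the same core, all judged in a functional assay on ECa-109 cells for inhibition, with ECa-109 cell line (Homo sapiens) as the target, read by sulforhodamine B assay; a lower number here means a stronger inhibitor, a higher number a weaker inhibitor. Compound 1 `O=C1C=C(Nc2ccc(I)cc2)C(=O)c2c1nc1n2[C@H]2OC[C@@H](O)[C@H]2OC1` carries a 4-iodophenyl group on its amine nitrogen, and in this assay compound 1 gives 2300 nM. Compound 2 `COc1cccc(NC2=CC(=O)c3nc4n(c3C2=O)[C@H]2OC[C@@H](O)[C@H]2OC4)c1` carries a 3-methoxyphenyl group in the same place, and in this assay compound 2 gives 7620 nM. That single exchange brought a 3.3-fold higher number from compound 1 to compound 2 (0.52 log units; beyond the scatter), so compound 2 stands as the higher of the two numbers, a weaker inhibitor than compound 1.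

Compound 3 `O=C1C=C(Nc2ccc(C(F)(F)F)cc2)C(=O)c2c1nc1n2[C@H]2OC[C@@H](O)[C@H]2OC1` has not yet been measured. It differs from compound 2 in one place: 4-(trifluoromethyl)phenyl in place of 3-methoxyphenyl on an amine nitrogen. Among the measured compounds shown here, only one measured step bears on this change, namely a 3.3-fold higher number from compound 1 to compound 2 (0.52 log units; beyond the scatter), which shows that a 4-iodophenyl group gave a lower number than the 3-methoxyphenyl group. Compound 3 returns to a substituted phenyl of the kind seen in compound 1 rather than compound 2. Compound 3 is therefore expected to roughly reverse that step, giving a 3.0-fold lower number from compound 2 to compound 3 (0.48 log units; beyond the scatter). The estimate for compound 3 is 2500 nM, expected to fall between 900 nM and 7000 nM.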

Compound 3, half-maximal inhibitory concentration: 5500 nM
Compound 3: middle estimate off by 2.2-fold (0.34 log units), on the low side; the range from low to high includes it.
By their numbers in this assay, from the lowest: compound 1; then compounds 3 and 2 (each within the scatter of the next).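

In this assay, placing 4-(trifluoromethyl)phenyl instead of 3-methoxyphenyl on the amine nitrogen gives a 1.4-fold lower number from compound 2 to compound 3 (0.14 log units; within the scatter) and so leaves compound 2 and compound 3 indistinguishable, even though the two groups differ in their substituent and where it sits on the ring. The comparison with compound 1 is the informative one: trifluoromethyl in place of iodo on an aromatic carbon gives a 2.4-fold higher number from compound 1 to compound 3 (0.38 log units; beyond the scatter) and shows that a change of this one substituent on the phenyl ring can register in this assay, leaving compound 1, with its 4-iodophenyl group, as the strongest inhibitor of the three. No supporting measurement is available to explain why iodo and trifluoromethyl differ here.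

Among the compounds shown here, with only three aryl groups to compare, it remains open whether the lower number of compound 1 is particular to iodo or would also appear with a 4-bromophenyl or 4-chlorophenyl group. A 4-methoxyphenyl or unsubstituted phenyl group on the same nitrogen would help separate the effect of the substituent's identity from that of its place on the ring.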